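The source may report more compounds than this note shows. Statements on the series, on what has been measured and on what is new or still open speak of the compounds shown alone.

Working notes on the series. Three analogues sharing one core are measured in an ADME assay on microsomes from liver (Homo sapiens) for metabolic stability, with a stated time of 10 min; a higher number here means that more of the compound is left, a lower number that less of the compound is left: compound 1 `CC(C)(C)NC(=O)NCCS(=O)(=O)NC(=O)c1ccc(Nc2nc(NC3(c4ccc(Cl)cc4)CC3)nc(OCC(F)(F)F)n2)cc1` gives 96%, compound 2 `CC(C)(C)OC(=O)NCCS(=O)(=O)NC(=O)c1ccc(Nc2nc(NC3(c4ccc(Cl)cc4)CC3)nc(OCC(F)(F)F)n2)cc1` gives 92%, and compound 3 `CC(C)C(=O)NCCS(=O)(=O)NC(=O)c1ccc(Nc2nc(NC3(c4ccc(Cl)cc4)CC3)nc(OCC(F)(F)F)n2)cc1` gives 86%. Compound 3 holds the lowest of the three numbers, but its gap to compound 2 and to compound 1 stays within the scatter. The next step leads to compound 4 `CC(C)OC(=O)NCCS(=O)(=O)NC(=O)c1ccc(Nc2nc(NC3(c4ccc(Cl)cc4)CC3)nc(OCC(F)(F)F)n2)cc1`, with isopropoxy in place of isopropyl on a carbonyl carbon. Among the measured compounds shown here, two measured steps bear on it: a number 4 percentage points lower from compound 1 to compound 2 (within the scatter) and a number 6 percentage points lower from compound 2 to compound 3 (within the scatter); both touch the same carbonyl carbon, both small. The present change reverses the kind of the second. Compound 4 is therefore expected to give 90%, ranging 80% to 98%, so the expected step is a number 4 percentage points higher from compound 3 to compound 4 (within the scatter), within the scatter.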

Compound 4, percent of the compound remaining: 100%
The estimate for compound 4 lay 10 percentage points below the measured number; the whole stated range lies below it.
By their numbers in this assay, from the lowest: compounds 3, 2, 1 and 4 (each within the scatter of the next, the first and the last beyond it).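

In this assay, among the compounds shown here, isopropoxy in place of isopropyl on this carbonyl carbon gives a number 14 percentage points higher from compound 3 to compound 4 (beyond the scatter) and is the only step that lies beyond the scatter. The other two steps, a number 8 percentage points higher from compound 2 to compound 4 (within the scatter) and a number 4 percentage points higher from compound 1 to compound 4 (within the scatter), stay within the scatter, so compound 4 is not separated from compound 2 or compound 1. No evidence at hand accounts for the size of the step from isopropyl to isopropoxy. Still open, from the compounds shown here alone, is whether a methoxy group, a longer alkoxy chain or a dimethylamino group on this carbonyl carbon would fall with compound 4 or with compound 3.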